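Changing the aryl group of a uridine triphosphate analog

A few compounds are considered here, and "the series" means these few. Any claim that something is new, unique, unknown or untested is made for them only; others in the source may bear on it.

Measured so far:
compound 1 `O=c1[nH]/c(=N\OCCOc2ccccc2)ccn1[C@@H]1O[C@H](COP(=O)(O)OP(=O)(O)OP(=O)(O)O)[C@@H](O)[C@H]1O`, 1780 nM
compound 2 `O=c1[nH]/c(=N\OCCCc2ccc(I)cc2)ccn1[C@@H]1O[C@H](COP(=O)(O)OP(=O)(O)OP(=O)(O)O)[C@@H](O)[C@H]1O`, 90 nM

Compound 2 gives the lowest number of the two in a functional assay on 1321-N1 cells for agonist activity at P2Y purinoceptor 6 (Homo sapiens), read by scintillation counting and inositol phosphate accumulation; on this read-out higher numbers stand for an effect only at larger amounts of compound and lower numbers for an effect already at smaller amounts; the nearest is compound 1, and the step of a 20-fold lower number from compound 1 to compound 2 (1.30 log units; beyond the scatter) lies beyond the scatter. Compound 3 `O=c1[nH]/c(=N\OCCCc2cccc([N+](=O)[O-])c2)ccn1[C@@H]1O[C@H](COP(=O)(O)OP(=O)(O)OP(=O)(O)O)[C@@H](O)[C@H]1O` differs from compound 2 by 3-nitrophenyl in place of 4-iodophenyl on a saturated chain carbon, three bonds along the chain from an oxygen. Among the compounds with values here, only one measured step exists, and it changed both the chain and the aryl group at once, so it bears on this change only loosely: it shows that the aryl end of the chain matters, but not what a nitro group in place of iodine does. With the chain kept and only the ring substituent changed, the expected step of a 3.3-fold higher number from compound 2 to compound 3 (0.52 log units; beyond the scatter) is a moderate rise in the number, with wide uncertainty. Compound 3 is therefore estimated at 300 nM, within a range of 80 nM to 1200 nM.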

Compound 3, half-maximal effective concentration: 9700 nM
Estimate against measurement, compound 3: 32-fold (1.51 log units) below; the whole stated range lies below it.
By their numbers in this assay, from the lowest: compound 2; then compound 1; then compound 3.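

In this assay, the end of the chain proves far more sensitive than the earlier pair could show: with the chain kept, exchanging 4-iodophenyl for 3-nitrophenyl gives a 110-fold higher number from compound 2 to compound 3 (2.03 log units; beyond the scatter). A benzyl-type end is also not better than phenoxy in itself, as 3-nitrobenzyl in place of phenoxy gives a 5.4-fold higher number from compound 1 to compound 3 (0.74 log units; beyond the scatter), the opposite direction to the step with 4-iodobenzyl. Nothing available explains why these ring groups differ so much.

The group and its place on the ring changed together, so the compounds shown cannot separate the loss tied to nitro from that tied to its ring position; 3-iodophenyl or 4-nitrophenyl would divide the two. As far as these compounds go, how an amine or a carboxylic acid on the same ring would behave also remains open.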